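The source may hold more compounds than are shown below. What is called first, only, known or untested is meant among the compounds shown, and "the series" means these compounds.

Measured compounds:
compound 1 `CNC(=O)C1=CC(C)(C)Oc2ccc(C#N)cc21` 66.6%
compound 2 `CNC(=O)C1=CC(C)(C)Oc2ccc([N+](=O)[O-])cc21` 61%
compound 3 `CCCNC(=O)C1=CC(C)(C)Oc2ccc([N+](=O)[O-])cc21` 74.1%

In a functional assay on the whole organism (muscle tissue) with Rattus norvegicus as the target (a higher number here means a larger maximal response, a lower number a smaller maximal response), compound 3 gives the highest of the three numbers; the gap to compound 1 is within the scatter, only the gap to compound 2 lies beyond it. Compound 4 `CC(C)NC(=O)C1=CC(C)(C)Oc2ccc([N+](=O)[O-])cc21` differs from compound 3 in one place: isopropyl in place of propyl on an amide-type nitrogen. Going by the values given here, no measured step rearranges the atoms of the substituent on this nitrogen. Among the compounds with values here, the only step at this position, a number 13.1 percentage points higher from compound 2 to compound 3 (beyond the scatter), is a modest gain from adding chain carbons; the remaining step, a number 5.6 percentage points lower from compound 1 to compound 2 (within the scatter), touches the aromatic substituent and lies within the scatter. With the same atoms kept on the nitrogen, the step is expected to stay within the scatter: a number 2.1 percentage points lower from compound 3 to compound 4 (within the scatter). Compound 4 is therefore estimated at 72% in this assay, with a range of 58% to 86%.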

Compound 4, intrinsic activity: the largest response reached, in percent of the reference agonist's: 77.6%
Compound 4: middle estimate off by 5.6 percentage points, on the low side; measured number inside the range.
By their numbers in this assay, from the lowest: compounds 2, 1, 3 and 4 (each within the scatter of the next, the first and the last beyond it).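

In this assay, isopropyl in place of propyl on the amide-type nitrogen gives a number 3.5 percentage points higher from compound 3 to compound 4 (within the scatter) and so does not separate the two compounds, although the same atoms are joined differently. Isopropyl in place of methyl gives a number 16.6 percentage points higher from compound 2 to compound 4 (beyond the scatter) and thus shows that the gain over methyl seen with propyl also holds for the branched chain. Nothing available explains either step.

From the compounds shown here alone, whether butyl, tert-butyl or cyclopropyl on this nitrogen keeps the response remains open. So does whether isopropyl behaves the same with nitrile in place of nitro on the aromatic carbon.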